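Methylpiperidine step carried onto the dichlorophenyl core

The source may report more compounds than this note shows. Statements on the series, on what has been measured and on what is new or still open speak of the compounds shown alone.

The series is read in a functional assay on A549 cells (Homo sapiens) for inhibition, read by MTT assay, with a stated time of 72 h; a lower number here means a stronger inhibitor, a higher number a weaker inhibitor. Compound 1 `COc1cc2c(Oc3ccc(NC(=O)c4nn(-c5ccccc5C(F)(F)F)c(=O)cc4C)cc3F)ccnc2cc1OCCCN1CCCCC1` gives 140 nM. Compound 2 `COc1cc2c(Oc3ccc(NC(=O)c4nn(-c5ccccc5C(F)(F)F)c(=O)cc4C)cc3F)ccnc2cc1OCCCN1CCC(C)CC1` gives 160 nM; the change between the two is methyl in place of hydrogen on a saturated ring carbon and the step it made is a 1.1-fold higher number from compound 1 to compound 2 (0.06 log units; within the scatter). Compound 3 `COc1cc2c(Oc3ccc(NC(=O)c4nn(-c5ccc(Cl)cc5Cl)c(=O)cc4C)cc3F)ccnc2cc1OCCCN1CCCCC1` gives 220 nM; it differs from compound 1 by 2,4-dichlorophenyl in place of 2-(trifluoromethyl)phenyl on an aromatic nitrogen, a step of a 1.6-fold higher number from compound 1 to compound 3 (0.20 log units; within the scatter). Compound 4 `COc1cc2c(Oc3ccc(NC(=O)c4nn(-c5ccc(Cl)cc5Cl)c(=O)cc4C)cc3F)ccnc2cc1OCCCN1CCC(C)CC1` has not yet been measured in this assay; it differs from compound 3 by methyl in place of hydrogen on a saturated ring carbon, the same change at the same place as that from compound 1 to compound 2, now carried onto the core of compound 3. The two cores differ as set out for compound 1 against compound 3, and nothing in the three measured compounds suggests that the methyl change behaves differently on the second core. Expected in this assay is a step of a 1.1-fold higher number from compound 3 to compound 4 (0.04 log units; within the scatter), resting on the earlier step of a 1.1-fold higher number from compound 1 to compound 2 (0.06 log units; within the scatter) lying within the scatter. Compound 4 is estimated at 240 nM, with a likely range from 130 nM to 450 nM.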

Compound 4, half-maximal inhibitory concentration: 200 nM
Estimate against measurement, compound 4: 1.2-fold (0.08 log units) above; the measured number falls inside the stated range.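

In this assay, methyl in place of hydrogen on the piperidine gives a 1.1-fold lower number from compound 3 to compound 4 (0.04 log units; within the scatter), and this step sits with the earlier one on the other core: the same change on two cores in this assay, a 1.1-fold higher number (0.06 log units; within the scatter) from compound 1 to compound 2 and a 1.1-fold lower number (0.04 log units; within the scatter) from compound 3 to compound 4, 1.3-fold (0.10 log units) apart, within the scatter of two such steps. With 2,4-dichlorophenyl in place of 2-(trifluoromethyl)phenyl on the aromatic nitrogen, the step on the methylpiperidine compounds is a 1.3-fold higher number from compound 2 to compound 4 (0.10 log units; within the scatter), and it also sits with its earlier counterpart: the same change on two cores in this assay, a 1.6-fold higher number (0.20 log units; within the scatter) from compound 1 to compound 3 and a 1.3-fold higher number (0.10 log units; within the scatter) from compound 2 to compound 4, 1.3-fold (0.10 log units) apart, within the scatter of two such steps. The four compounds therefore show that both changes are tolerated on either core without a step beyond the scatter, but they do not show that an effect transfers between cores, as all four steps are too small to separate from repeat noise.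

Still open, as far as these compounds go, is whether a hydroxyl or a carboxylic acid in place of the methyl would give a step beyond the scatter. Also open, from the compounds shown here alone, is whether such a step, or one from a nitrile on the aromatic ring carried by the nitrogen, would hold on both cores.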